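Replacing Iodo with 3-Acetylphenyl on an Antiproliferative Amide

This account rests on a few compounds, and the source may have more. Where it says the series, first, only, none or still open, it means among the compounds named here.

Measured compounds:
Compound 1, `CC(C)(C)NC(=O)CCc1cccc2c1B(O)OC2`; in a functional assay on MDA-MB-231 cells (Homo sapiens) for antiproliferative activity, read by MTT assay, with a stated time of 72 h (a lower number here means a stronger inhibitor, a higher number a weaker inhibitor), compound 1 gives > 100000 nM, a limit of the assay rather than a number.
Compound 2, `O=C(CCc1cccc2c1B(O)OC2)Nc1nccs1`; compound 2 gives > 100000 nM, again a limit.
Compound 3, `O=C(CCc1cccc2c1B(O)OC2)Nc1cccc(I)c1`; compound 3 gives 5300 nM.

Within the data shown here, compound 3 therefore holds the only number in this set; the two other values sit at a limit, as the limit of > 100000 nM in this assay, at which 2 of the 3 values shown sit, records. The two readable steps are both large: an at least 18-fold lower number from compound 1 to compound 3 (1.27 log units; beyond the scatter) and an at least 18-fold lower number from compound 2 to compound 3 (1.27 log units; beyond the scatter). The step that the two limits leave unreadable from compound 1 to compound 2 cannot be sized, since both ends are limits.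

Compound 4, `CC(=O)c1cccc(-c2cccc(NC(=O)CCc3cccc4c3B(O)OC4)c2)c1`, differs from compound 3 by 3-acetylphenyl in place of iodo on an aromatic carbon. Among the measured compounds shown here, none of the measured steps touches this place: all three exchange the whole group on the amide-type nitrogen, whereas here the 3-iodophenyl is kept and only its iodo is exchanged. The measured steps thus give no direct guide, and the author expects a step no larger than the scatter, perhaps a modest improvement. Compound 4 is estimated at 3000 nM, between 800 nM and 15000 nM, meaning an expected step of a 1.8-fold lower number from compound 3 to compound 4 (0.25 log units; within the scatter).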

Compound 4, half-maximal inhibitory concentration: 52 nM
For compound 4 the middle estimate is 58-fold (1.76 log units) above the measured one; measured number outside the range, below it.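

Compound 3 and the two compounds before it differ only in the whole group on the amide-type nitrogen, so they said nothing about the iodo itself. In this assay, exchanging that iodo for 3-acetylphenyl on the aromatic carbon gives a 100-fold lower number from compound 3 to compound 4 (2.01 log units; beyond the scatter), which shows that this place, meta to a large group, can carry a much larger substituent with a new aromatic ring and still move the number far in the stronger direction. The data shown offer no explanation for the size of this step.

From the compounds shown here alone, it remains open whether the added ring alone or its acetyl accounts for the step, a question that a plain phenyl at this carbon would address. An amine or a carboxylic acid in place of the acetyl would show how far the step depends on that group.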